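The source may report more compounds than this note shows. Statements on the series, on what has been measured and on what is new or still open speak of the compounds shown alone.

In an ADME assay on L929 cells (Mus musculus) for cytotoxicity, read by resazurin assay, with a stated time of 48 h (on this read-out lower numbers stand for higher toxicity in this test and higher numbers for lower toxicity in this test), two compounds have numbers so far:
Compound 1 `C=CCn1c2ccc([N+](=O)[O-])cc2c(=O)n1Cc1ccccc1` gives 192000 nM
Compound 2 `CCOC(=O)n1c2ccc([N+](=O)[O-])cc2c(=O)n1Cc1ccccc1` gives 122000 nM

Compound 2 at 122000 nM lies within the scatter of compound 1, so the two cannot be told apart. Compound 3 `O=C(OCc1ccccc1)n1c2ccc([N+](=O)[O-])cc2c(=O)n1Cc1ccccc1` differs from compound 2 by phenyl in place of methyl on a saturated chain carbon bound to an oxygen next to a carbonyl group and so carries benzyloxycarbonyl where compound 2 carries ethoxycarbonyl. Among the measured compounds shown here, the only measured step that bears on this group is a 1.6-fold lower number from compound 1 to compound 2 (0.20 log units; within the scatter) with ethoxycarbonyl in place of allyl on an aromatic nitrogen, and that step stays within the scatter. For the measured compounds named here, no measured pair shows phenyl in place of methyl, so the data point in neither direction. The expected change is a 1.1-fold lower number from compound 2 to compound 3 (0.04 log units; within the scatter) and no step beyond the scatter is expected. In this assay the estimated value for compound 3 is 110000 nM with an expected range from 50000 nM to 230000 nM once measured.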

Compound 3, concentration lethal to 50% of the cells: 86100 nM
The estimate for compound 3 lay 1.3-fold (0.11 log units) above the measured number; measured number inside the range.
By their numbers in this assay, from the lowest: compounds 3, 2 and 1 (each within the scatter of the next, the first and the last beyond it).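

Putting phenyl in place of methyl on a saturated chain carbon bound to an oxygen next to a carbonyl group gives a 1.4-fold lower number from compound 2 to compound 3 (0.15 log units; within the scatter), so benzyloxycarbonyl and ethoxycarbonyl cannot be told apart in this assay. Among the compounds shown here, the wider comparison, however, gives a 2.2-fold lower number from compound 1 to compound 3 (0.35 log units; beyond the scatter), the first step at this position to pass beyond the scatter, though only modestly. Nothing available explains this small separation.

The compounds shown leave open how an amine or a carboxylic acid in place of phenyl on this chain carbon would read in this assay. They also leave open whether a longer chain in place of allyl on the aromatic nitrogen would stay within the scatter of compound 1.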